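Pyridin-2-yl on the piperazine of compound 1

The compounds below may be only part of what the source reports. "The series", "measured", "known", "first", "only" and "open" are said of these compounds alone.

Measured compounds:
compound 1 `Cc1ccc(N2CCN(C(=S)SCc3ccc4nc(N)nc(N)c4c3)CC2)c(C)c1`, 3190 nM
compound 2 `Nc1nc(N)c2cc(CSC(=S)N3CCN(c4ccc(Cl)c(Cl)c4)CC3)ccc2n1`, 3060 nM
compound 3 `Nc1nc(N)c2cc(CSC(=S)N3CCN(c4ccccc4F)CC3)ccc2n1`, 6660 nM

In a functional assay on HeLa cells (Homo sapiens) for antiproliferative activity, read by MTT assay, with a stated time of 72 h (a lower number here means a stronger inhibitor, a higher number a weaker inhibitor), compound 1 stands second highest of the three numbers; compound 2 lies within the scatter of it, with a 1.0-fold lower number from compound 1 to compound 2 (0.02 log units; within the scatter), while compound 3 gives a modest step, a 2.1-fold higher number from compound 1 to compound 3 (0.32 log units; beyond the scatter). Compound 4 `Nc1nc(N)c2cc(CSC(=S)N3CCN(c4ccccn4)CC3)ccc2n1` differs from compound 1 by pyridin-2-yl in place of 2,4-dimethylphenyl on an amine nitrogen in a ring. Among the measured compounds shown here, no measured step carries this exact change, but all three aryl swaps on the same nitrogen stayed within a modest range. Compound 4 is therefore expected to give 4500 nM, between 2000 nM and 12000 nM, a step of a 1.4-fold higher number from compound 1 to compound 4 (0.15 log units; within the scatter).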

Compound 4, half-maximal inhibitory concentration: 5090 nM
Estimate against measurement, compound 4: 1.1-fold (0.05 log units) below, and the stated range covers the measured number.
By their numbers in this assay, from the lowest: compounds 2, 1, 4 and 3 (each within the scatter of the next, the first and the last beyond it).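

In this assay, pyridin-2-yl, the first aromatic ring here with a hetero atom and a hydrogen-bond acceptor, stays within the scatter of all three aryl compounds (a 1.6-fold higher number from compound 1 to compound 4 (0.20 log units; within the scatter); a 1.7-fold higher number from compound 2 to compound 4 (0.22 log units; within the scatter); a 1.3-fold lower number from compound 3 to compound 4 (0.12 log units; within the scatter)). Among the compounds shown here, compound 4 therefore forms no step of its own at this amine nitrogen, although compound 3 stands modestly apart from compound 1 and compound 2. Nothing available accounts for these numbers.

The compounds shown leave open how a non-aromatic group on the same nitrogen, such as benzyl, cyclohexyl or acetyl, would read. They also leave open whether pyridin-4-yl would match pyridin-2-yl.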